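A few compounds are considered here, and "the series" means these few. Any claim that something is new, unique, unknown or untested is made for them only; others in the source may bear on it.

In a functional assay on PC-3 cells (Homo sapiens) for inhibition, read by sulforhodamine B assay, with a stated time of 72 h (a higher number here means a weaker inhibitor, a lower number a stronger inhibitor), compound 3 (`CS(=O)(=O)Nc1sc(-c2ccc(Cl)cc2)c(-c2ccc(Cl)cc2)c1C(=O)NC1CC1`) is recorded as "not determined" (no result reported), with no result reported, so the step to compound 4 (`Nc1sc(-c2ccc(Cl)cc2)c(-c2ccc(Cl)cc2)c1C(=O)NC1CC1`) starts from nothing measured. The change is hydrogen in place of methylsulfonyl on a nitrogen on an aromatic ring, or methanesulfonamido to amino. Among the compounds with values here, no measured step covers this change, so no size or direction can be expected for it. Within the data shown here, the only measured step, a 3.4-fold higher number from compound 1 to compound 2 (0.54 log units; beyond the scatter), is modest, lies beyond the scatter and sits on a carbonyl carbon instead. Still, compound 4 keeps the amino of compound 1 (`Nc1sc(-c2ccc(Cl)cc2)c(-c2ccc(Cl)cc2)c1C(=O)N1CCC(=O)CC1=O`), which gives 9230 nM in this assay, and of compound 2 (`Nc1sc(-c2ccc(Cl)cc2)c(-c2ccc(Cl)cc2)c1C(=O)NCc1ccccc1`), which gives 31800 nM there. For compound 4 the expected value is 15000 nM, with 5000 nM to 45000 nM as the estimated range.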

Compound 4, half-maximal inhibitory concentration: 3680 nM
Compound 4: the middle estimate sits 4.1-fold (0.61 log units) above what was measured; the whole stated range lies above it.
By their numbers in this assay, from the lowest: compound 4; then compound 1; then compound 2.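

Swapping benzyl for cyclopropyl on the amide-type nitrogen in this assay gives an 8.6-fold lower number from compound 2 to compound 4 (0.94 log units; beyond the scatter), and cyclopropylamino in place of 2,4-dioxopiperidin-1-yl gives a 2.5-fold lower number from compound 1 to compound 4 (0.40 log units; beyond the scatter). Both steps make compound 4 the strongest inhibitor of the three with results, showing that changes at this carbonyl can lower the number as well as raise it. No measurement available here explains these differences. From the compounds shown here alone, whether an ethyl chain or a cyclobutyl ring on the amide nitrogen would lower the number further remains open. The change from methanesulfonamido to amino cannot be read, since compound 3 has no result.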